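The compounds below may be only part of what the source reports. "The series", "measured", "known", "first", "only" and "open" are said of these compounds alone.

Compound 1 (`COc1ccc(C23CCC(=O)N2CCCO3)cc1`) was studied in a functional assay on the whole organism (Central nervous system) for activation, with Mus musculus as the target; a higher number here means that more compound is needed for the effect, a lower number that less compound is needed. In this assay compound 1 gives < 150 mg/kg, which is a limit of the assay and not a full number. Two further compounds give a sense of the range of results. Compound 2 (`O=C1CCCC2(c3ccccc3)OCCCN12`) in this assay gives < 50 mg/kg, again a limit rather than a number. Going by the values given here, compound 3 (`O=C(CCC(=O)c1ccc(Cl)c(Cl)c1)NCCCO`) gives 300 mg/kg in this assay, the only complete value among the three. Compound 1 therefore sits at the limit of < 150 mg/kg in this assay, at which 1 of the 3 values shown sits, while compound 2 sits at the limit of < 50 mg/kg in this assay, at which 1 of the 3 values shown sits, so neither can be placed exactly against compound 3.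

Compound 4 (`Cc1ccc(C23CCC(=O)N2CCCO3)cc1`) differs from compound 1 in a single place: methyl in place of methoxy on an aromatic carbon. Among the compounds with values here, no pair of measured compounds shows this same change, so there is no measured step to compare it with. The expected step is a step that the limit leaves unreadable from compound 1 to compound 4, which is meant as nothing beyond the usual scatter of the assay in either direction. On that basis compound 4 is estimated at 90 mg/kg in this assay, with a likely range from 35 mg/kg to 220 mg/kg.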

Compound 4, dose for half-maximal effect: < 50 mg/kg
Compound 4: a limit, no number; the forecaster's own chance of this, stated with the estimate: 55%; middle value at least 1.8-fold (0.25 log units) from the limit.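

In this assay compound 4 gives < 50 mg/kg, which is a limit of the assay and not a number. Compound 1 also stands only as a limit, and the step between compound 1 and compound 4 cannot be read. The compounds shown leave open whether methyl in place of methoxy changes the dose needed, in which direction and by how much.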